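The source may report more compounds than this note shows. Statements on the series, on what has been measured and on what is new or still open speak of the compounds shown alone.

Measured in a functional assay on MCF7 cells (Homo sapiens) for antiproliferative activity, read by MTT assay, with a stated time of 48 h; on this read-out higher numbers stand for weaker inhibition and lower numbers for stronger inhibition:
- compound 1 `CNCC(=O)Nc1cc(OC)ccc1C(=O)c1ccc2c(c1)C=CC(C)(C)O2`: 1210 nM
- compound 2 `C=C(c1ccc(OC)cc1NC(=O)CO)c1ccc(OC)c2c1OC(C)(C)C=C2`: 100 nM
- compound 3 `C=C(c1cc(OC)c(OC)c(OC)c1)c1ccc(OC)cc1NC(=O)CO`: 110 nM

Compound 2 at 100 nM lies within the scatter of compound 3 at 110 nM. The gap from compound 2 to compound 1 at 1210 nM is beyond the scatter, with compound 1 showing the higher number and so the weaker inhibition.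

The next compound to consider is compound 4 `C=C(c1ccc(OC)cc1NC(=O)CN)c1ccc(OC)c2c1OC(C)(C)C=C2`, reached from compound 2 by one change: amino in place of hydroxy on a saturated chain carbon bound to a carbonyl carbon.

For the measured compounds named here, no measured pair isolates this change. Compound 2 differs from compound 1 in more than one place, so compound 1 at 1210 nM gives no clean reading of it. The expectation therefore rests on the size of the change alone and remains loose. No step beyond the scatter is expected in this assay, with a slight lean towards a higher number. The estimated step is a 1.3-fold higher number from compound 2 to compound 4 (0.11 log units; within the scatter). The estimate in this assay for compound 4 is 130 nM, with an expected range of 40 nM to 450 nM.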

Compound 4, half-maximal inhibitory concentration: 220 nM
For compound 4 the middle estimate is 1.7-fold (0.23 log units) below the measured one, and the stated range covers the measured number.
By their numbers in this assay, from the lowest: compounds 2, 3 and 4 (each within the scatter of the next, the first and the last beyond it); then compound 1.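

In this assay, for the compounds shown here, the exchange of hydroxy for amino on a saturated chain carbon bound to a carbonyl carbon gives a 2.2-fold higher number from compound 2 to compound 4 (0.34 log units; beyond the scatter) and provides the first reading of this position from a pair that differs in one place. The earlier compounds shown here offered no such pair, and the position could not be judged from them. Here one heavy atom changes, oxygen to nitrogen, with the hydrogen-bond donor and acceptor counts of the group and its net charge unchanged, yet the modest step still lies beyond the usual scatter. Nothing at hand accounts for the step.

Open, on these data alone, is whether a dimethylamino group, a methoxy group or a carboxylic acid in this place would read closer to hydroxy or to amino, and whether a longer chain between the carbonyl and the end group would keep the step. Also open, as far as these compounds go, is whether the same exchange on the core of compound 3 would give a step of similar size.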